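The compounds below may be only part of what the source reports. "The series", "measured", "known", "first", "only" and "open" are said of these compounds alone.

Compound 1 `Cc1nnsc1C(=O)Nc1nc2cc(C(C)(C)C)ccc2o1` gives 6730 nM in an ADME assay on HEK293 cells (Homo sapiens) for cytotoxicity, read by CCK-8 assay, with a stated time of 48 h; on this read-out higher numbers stand for weaker inhibition and lower numbers for stronger inhibition. Compound 2 `O=C(Nc1nc2ccccc2o1)c1cccs1` gives 81900 nM in this assay.

Among the measured compounds shown here, of the two numbers in this assay, compound 2 stands highest; the only neighbour, compound 1, sits well below it, and that gap lies beyond the scatter. Compound 3 `O=C(Nc1nc2ccccc2o1)c1ccccc1` differs from compound 2 by phenyl in place of thiophen-2-yl on a carbonyl carbon. For the measured compounds named here, no pair of measured compounds shows the effect of such a swap, so nothing here points to a change in either direction. Compound 3 is therefore expected to stay close to compound 2, with a step of a 1.0-fold lower number from compound 2 to compound 3 (0.01 log units; within the scatter) that is not expected to exceed the scatter. The estimated value of compound 3 in this assay is 80000 nM, in a range from 30000 nM to 200000 nM.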

Compound 3, half-maximal inhibitory concentration: > 100000 nM
Compound 3: a limit, no number; the forecaster's own chance of this, stated with the estimate: 20%; middle value at least 1.2-fold (0.09 log units) away from the limit.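

In this assay, among the compounds shown here, the step of an at least 1.2-fold higher number from compound 2 to compound 3 (0.08 log units; that floor lies within the scatter) is the first reading of a change on this carbonyl carbon, and it shows that phenyl in place of thiophen-2-yl brings no fall in the number. The value of compound 3 is a limit and not a number, so this step gives only a floor and its full size cannot be read: the limit of > 100000 nM in this assay, at which 1 of the 3 values shown sits. Still open, on these data alone, is whether an amine or a carboxylic acid on the phenyl would bring the number down to a readable value in this assay.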